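The source may report more compounds than this note shows. Statements on the series, on what has been measured and on what is new or still open speak of the compounds shown alone.

Measured compounds:
compound 1 `COc1cc2ncnc(Nc3cccc(C#N)c3)c2cc1OC` — "not active" (no number reported)
compound 2 `COc1cc2ncnc(Nc3cccc(B(O)O)c3)c2cc1OC` — "not active" (no number reported)
compound 3 `COc1cc2ncnc(Nc3cccc(C(=O)O)c3)c2cc1OC` — 32%

Three compounds on the shared core, each carrying a different group on the outer part of the molecule. In an assay on isolated protein for inhibition of vascular endothelial growth factor receptor 1 (Homo sapiens), read by ELISA, with a stated time of 20 min, tested at 1 uM (a lower number here means less inhibition, a higher number more inhibition at the concentration tested (going by the name of the read-out)), compound 3 gives 32%. Compound 1 in this assay is reported as "not active" (no number reported) without a number, and compound 2 likewise as "not active" (no number reported). Compound 3 thus stands as the single entry with a reported number; the other two entries give nothing to rank against it, so no ordering of the three can be drawn beyond the fact that compound 3 alone shows measurable inhibition here.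

Compound 4 `COC(=O)c1cccc(Nc2ncnc3cc(OC)c(OC)cc23)c1` is not yet measured in this assay. It differs from compound 3 by methyl in place of hydrogen on an oxygen next to a carbonyl group. Going by the values given here, no step between two measured compounds exists in this set, so the effect of this change cannot be read from the data; the only anchor is the number for compound 3. A step of modest size is expected, more likely downward than upward, and quite possibly within the scatter, estimated as a number 10 percentage points lower from compound 3 to compound 4 (within the scatter). Compound 4 is therefore expected to give 22%, within a range from 2% to 42%, with a real chance that only a limit and no number is reported.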

Compound 4, a percentage reported as inhibition, at one concentration (the size of the read-out at that concentration, not a potency): "not active" (no number reported)
Nothing numeric was reported for compound 4, so the estimate cannot be set against anything.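

In this assay, going by these compounds alone, compound 4 carries no number, so no step from compound 3 to it can be read. No measured evidence bears on this result. The compounds shown leave open how far carboxy to methoxycarbonyl shifts inhibition, and where compound 1 and compound 2 rank against compound 3.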